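A few compounds are considered here, and "the series" means these few. Any claim that something is new, unique, unknown or untested is made for them only; others in the source may bear on it.

Measured in a functional assay on MOLT-4 cells (Homo sapiens) for antiproliferative activity; on this read-out lower numbers stand for stronger inhibition and higher numbers for weaker inhibition:
- compound 1 `COc1cc(C(=O)c2sc(-c3ccc(Br)cc3)cc2N)cc(OC)c1OC`: 92 nM
- compound 2 `COc1cc(C(=O)c2sc(-c3ccc(Cl)cc3)cc2N)cc(OC)c1OC`: 77 nM
- compound 3 `COc1cc(C(=O)c2sc(-c3cccc([N+](=O)[O-])c3)cc2N)cc(OC)c1OC`: 7.5 nM

Compound 3 has the lowest number of the three, and both of its steps to the others lie beyond the scatter. The next change gives compound 4 `COc1cc(C(=O)c2sc(-c3ccc(Cl)c(Cl)c3)cc2N)cc(OC)c1OC`, with 3,4-dichlorophenyl in place of 3-nitrophenyl on an aromatic carbon.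

Among the compounds with values here, three measured steps bear on this. Both a 12-fold lower number from compound 1 to compound 3 (1.09 log units; beyond the scatter) and a 10-fold lower number from compound 2 to compound 3 (1.01 log units; beyond the scatter) are large, while a 1.2-fold lower number from compound 1 to compound 2 (0.08 log units; within the scatter) stays within the scatter. A large step to a higher number is therefore expected in this assay, roughly the second of these in reverse, as compound 2, also a chlorophenyl, gives 77 nM. Within the data shown here, no measured compound carries the 3,4-dichlorophenyl group, so the range stays wide. The expected step is an 8.0-fold higher number from compound 3 to compound 4 (0.90 log units; beyond the scatter). For compound 4 the estimated value is 60 nM, with an expected range of 18 nM to 200 nM.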

Compound 4, half-maximal inhibitory concentration: 270 nM
For compound 4 the middle estimate is 4.5-fold (0.65 log units) below the measured one; measured number outside the range, above it.
By their numbers in this assay, from the lowest: compound 3; then compounds 2 and 1 (each within the scatter of the next); then compound 4.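

In this assay, within the data shown here, a 36-fold higher number from compound 3 to compound 4 (1.56 log units; beyond the scatter), the largest step at this position so far, and it separates the 3-nitrophenyl group further from the halogen-bearing phenyl groups. A second chloro on the phenyl ring is not neutral, giving a 3.5-fold higher number from compound 2 to compound 4 (0.54 log units; beyond the scatter), and the 3,4-dichlorophenyl group also gives a 2.9-fold higher number from compound 1 to compound 4 (0.47 log units; beyond the scatter), although the bromo-to-chloro swap stayed within the scatter. Nothing available explains these shifts.

Open, as far as these compounds go, is whether the nitro group itself is needed on the phenyl ring. An amine or a nitrile in its place would test this.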